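A few compounds are considered here, and "the series" means these few. Any claim that something is new, unique, unknown or untested is made for them only; others in the source may bear on it.

Compound 3 `CN(C)CCn1cnnc1-c1cc(Oc2ccc(NC(=O)N/N=C/c3ccc(F)cc3)cc2F)ccn1` belongs to a small series that shares one core and varies only the aryl group on the carbon with a double bond to nitrogen. In a functional assay on MKN-45 cells (Homo sapiens) for cytotoxicity, read by MTT assay, with a stated time of 72 h (on this read-out higher numbers stand for weaker inhibition and lower numbers for stronger inhibition), compound 3 gives 1030 nM, which puts it second highest of the three numbers measured. Its nearest neighbour is compound 1 `CN(C)CCn1cnnc1-c1cc(Oc2ccc(NC(=O)N/N=C/c3ccc(Cl)cc3Cl)cc2F)ccn1`, which in this assay gives 750 nM; the gap a 1.4-fold higher number from compound 1 to compound 3 (0.14 log units; within the scatter) lies within the scatter. For the measured compounds named here, compound 2 `CN(C)CCn1cnnc1-c1cc(Oc2ccc(NC(=O)N/N=C/c3ccc(O)c(Br)c3)cc2F)ccn1` in this assay gives 1860 nM, and the step of a 1.8-fold lower number from compound 2 to compound 3 (0.26 log units; within the scatter) also lies within the scatter, while a 2.5-fold higher number from compound 1 to compound 2 (0.39 log units; beyond the scatter) is the only step in the set that goes beyond it.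

Compound 4 `CN(C)CCn1cnnc1-c1cc(Oc2ccc(NC(=O)N/N=C/c3ccc(O)c(O)c3)cc2F)ccn1` differs from compound 3 in one place: 3,4-dihydroxyphenyl in place of 4-fluorophenyl on a carbon with a double bond to nitrogen. The step that bears most on this change is the one to the hydroxy-bearing aryl, compound 2, since a 2.5-fold higher number from compound 1 to compound 2 (0.39 log units; beyond the scatter) was modest but beyond the scatter, whereas the halogen-only exchange a 1.4-fold higher number from compound 1 to compound 3 (0.14 log units; within the scatter) was within it. On that basis compound 4 is expected to show a modest rise in this assay, estimated as a 2.1-fold higher number from compound 3 to compound 4 (0.33 log units; beyond the scatter). The estimate for compound 4 in this assay is therefore 2200 nM, with a range from 900 nM to 5500 nM.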

Compound 4, half-maximal inhibitory concentration: 3240 nM
For compound 4 the middle estimate is 1.5-fold (0.17 log units) below the measured one, and the stated range covers the measured number.
By their numbers in this assay, from the lowest: compounds 1, 3, 2 and 4 (each within the scatter of the next, the first and the last beyond it).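

In this assay, for the compounds shown here, 3,4-dihydroxyphenyl in place of 4-fluorophenyl on a carbon with a double bond to nitrogen gives a 3.1-fold higher number from compound 3 to compound 4 (0.50 log units; beyond the scatter) and is the first step away from 4-fluorophenyl at this position to go beyond the scatter, which the single hydroxy of compound 2 had not done; the same aryl group, set against 2,4-dichlorophenyl, gives a 4.3-fold higher number from compound 1 to compound 4 (0.64 log units; beyond the scatter) and is the largest step. Hydroxy in place of bromo on an aromatic carbon gives a 1.7-fold higher number from compound 2 to compound 4 (0.24 log units; within the scatter) and stays within the scatter, so the two hydroxy-bearing aryl groups cannot be told apart, and only the halogen-only aryl groups of compound 1 and compound 3 can be set against compound 4 with a clear gap. Nothing available here explains why the numbers rise with this exchange.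

What the compounds shown leave open is whether the rise follows the free hydroxy groups themselves or the 3,4-pattern of substitution, a question that a 3,4-dimethoxyphenyl or a 4-hydroxyphenyl group on the same carbon would address. As far as these compounds go, it is also open whether an amine or a carboxylic acid on this aryl ring would behave like hydroxy.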